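Thiophene in place of isoquinoline at the aryl ether

The source may report more compounds than this note shows. Statements on the series, on what has been measured and on what is new or still open speak of the compounds shown alone.

Working notes on a set of shared-core acids read in a functional assay for inhibition, with Homo sapiens as the target; on this read-out higher numbers stand for weaker inhibition and lower numbers for stronger inhibition. Compound 1 `CC(C)(C)Sc1c(CC(C)(C)C(=O)O)n(Cc2ccc(Cl)cc2)c2ccc(OCc3cc4ccccc4cn3)cc12` gives 3 nM in this assay; compound 2 `CC(C)(C)Sc1c(CC(C)(C)C(=O)O)n(Cc2ccc(Cl)cc2)c2ccc(OCc3nc4ccccc4s3)cc12` gives 3 nM; compound 3 `C[C@@H](COc1ccc2c(c1)c(SC(C)(C)C)c(CC(C)(C)C(=O)O)n2Cc1ccc(Cl)cc1)c1ccccn1` gives 2 nM. Compound 1 thus stands level with compound 2 at the digits shown, the two together being the highest of the three numbers, and sits closest to compound 2 with no change at the digits printed from compound 1 to compound 2 (within the scatter); the step of a 1.5-fold lower number from compound 1 to compound 3 (0.18 log units; within the scatter) to compound 3 stays within the scatter as well, as does a 1.5-fold lower number from compound 2 to compound 3 (0.18 log units; within the scatter).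

Compound 4 `CC(C)(C)Sc1c(CC(C)(C)C(=O)O)n(Cc2ccc(Cl)cc2)c2ccc(OCc3cccs3)cc12` is not yet measured. It differs from compound 1 as follows: thiophen-2-yl in place of isoquinolin-3-yl on a saturated chain carbon bound to an oxygen on an aromatic ring

Within the data shown here, the steps that bear on this are the two exchanges at the same place, from compound 1 to compound 2 and from compound 1 to compound 3, neither of which moved this assay beyond the scatter. Among the measured compounds shown here, no measured step covers a five-membered ring at this position. On that basis the step of a 1.3-fold higher number from compound 1 to compound 4 (0.12 log units; within the scatter) is expected to stay within the scatter, with no direction favoured. Compound 4 is therefore estimated at 4 nM in this assay, with a range from 1.5 nM to 12 nM.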

Compound 4, half-maximal inhibitory concentration: 4 nM
Beside the measured number, compound 4's estimate shows no gap at the digits printed; the measured number falls inside the stated range.
By their numbers in this assay, from the lowest: compounds 3, 1, 2 and 4 (each within the scatter of the next).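

In this assay, the place on a saturated chain carbon bound to an oxygen on an aromatic ring also accepts a single five-membered aromatic ring: thiophen-2-yl in place of isoquinolin-3-yl gives a 1.3-fold higher number from compound 1 to compound 4 (0.12 log units; within the scatter), and the exchange for 1,3-benzothiazol-2-yl gives a 1.3-fold higher number from compound 2 to compound 4 (0.12 log units; within the scatter). The exchange for 1-(pyridin-2-yl)ethyl gives a 2.0-fold higher number from compound 3 to compound 4 (0.30 log units; within the scatter), so all three new steps stay within the scatter and neither a second fused ring nor a ring nitrogen is required at this place for this read-out. Nothing available accounts for this flat response.

Every group shown here carries an aromatic ring, so a cyclohexyl ring, a plain butyl chain, an amine or a carboxylic acid at this place remains open. As far as these compounds go, whether the same tolerance holds with another group in place of the 4-chlorobenzyl on the shared core also remains open.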